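A few compounds are considered here, and "the series" means these few. Any claim that something is new, unique, unknown or untested is made for them only; others in the source may bear on it.

Measured in a functional assay on MCF7 cells (Homo sapiens) for cytotoxicity, read by WST assay, with a stated time of 72 h; a higher number here means a weaker inhibitor, a lower number a stronger inhibitor:
- compound 1 `O=C1Nc2c(ccc(F)c2F)C1(c1ccc(O)cc1)c1ccc(F)c(F)c1`: 7.8 nM
- compound 2 `O=C1Nc2c(ccc(F)c2F)C1(c1ccc(O)cc1)c1cccs1`: 82 nM
- compound 3 `O=C1Nc2c(ccc(F)c2F)C1(c1ccc(O)cc1)c1cccnc1`: 63 nM

Compound 3, at 63 nM, matches compound 2 within the scatter, a 1.3-fold lower number from compound 2 to compound 3 (0.11 log units; within the scatter). It lies well away from compound 1, an 8.1-fold higher number from compound 1 to compound 3 (0.91 log units; beyond the scatter). Compound 4 `O=C1Nc2c(ccc(F)c2F)C1(c1ccc(O)cc1)C1CCCCCCC1` has cyclooctyl in place of pyridin-3-yl on a saturated ring carbon, (cyclooctyl in place of pyridin-3-yl on a saturated ring carbon). The same position also gave an 11-fold higher number from compound 1 to compound 2 (1.02 log units; beyond the scatter), so changes here can count for much. Yet no measured compound has a non-aromatic ring at this position, which leaves the direction open, with only a slight lean towards compound 1. No step beyond the scatter is expected in this assay, the estimated step being a 1.8-fold lower number from compound 3 to compound 4 (0.26 log units; within the scatter). Compound 4 is estimated at 35 nM, with an expected range of 6 nM to 200 nM.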

Compound 4, half-maximal inhibitory concentration: > 1000 nM
Compound 4: no number, only a limit; the forecaster's own chance of this, stated with the estimate: 3%; middle value at least 28-fold (1.45 log units) away from the limit.
By their numbers in this assay, from the lowest: compound 1; then compounds 3 and 2 (each within the scatter of the next). At a limit, above all of these: compound 4.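

In this assay compound 4, with cyclooctyl on the saturated ring carbon, gives a limit and not a number: the limit of > 1000 nM in this assay, at which 1 of the 4 values shown sits. Even so, the steps can be read: an at least 15-fold higher number from compound 3 to compound 4 (1.20 log units; beyond the scatter) and an at least 12-fold higher number from compound 2 to compound 4 (1.08 log units; beyond the scatter) and an at least 120-fold higher number from compound 1 to compound 4 (2.10 log units; beyond the scatter) all lie beyond the scatter. This position therefore does not tolerate every ring: the three aromatic rings gave measured numbers, while the only non-aromatic ring shown lies beyond all three.

The compounds shown do not separate the loss of aromaticity from the size of the eight-membered ring. Cyclopentyl or cyclohexyl here would bear on that question, and a piperidine ring or an open butyl chain remains unexplored among these compounds.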